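This account rests on a few compounds, and the source may have more. Where it says the series, first, only, none or still open, it means among the compounds named here.

Measured compounds:
compound 1 `O=C1COc2ccc(-c3cccc(NS(=O)(=O)c4ccc(F)cc4)c3)cc2N1c1ccccc1`, > 40000 nM
compound 2 `COc1ccc(N2C(=O)COc3ccc(-c4cnc(OC)c(NS(=O)(=O)c5ccc(F)cc5)c4)cc32)cc1`, 1350 nM
compound 3 `O=C1COc2ccc(-c3cnc4ccccc4c3)cc2N1c1ccccc1`, > 40000 nM

In a functional assay on A549 cells (Homo sapiens) for antiproliferative activity, read by MTT assay, with a stated time of 72 h (on this read-out lower numbers stand for stronger inhibition and higher numbers for weaker inhibition), compound 1 gives > 40000 nM, which is a limit of the assay and not a number. Compound 3 gives > 40000 nM in this assay, again a limit. Compound 2 is the only one of the three with a number, 1350 nM in this assay. Where compound 1 stands is therefore set by the limit of > 40000 nM in this assay, at which 2 of the 3 values shown sit; it is one of the two compounds whose activity this assay could not resolve. Within the data shown here, no pair of the measured compounds differs in a single place, so no measured step is available, and compound 2 differs from compound 1 in more than one part of the structure, so what its value shows cannot be attributed to any one part.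

Compound 4 `O=C1COc2ccc(-c3cccc(NS(=O)(=O)c4ccc(F)cc4)c3)cc2N1c1ccc(F)cc1` is the next compound in the series. It differs from compound 1 by fluoro in place of hydrogen on an aromatic carbon. Nothing measured here speaks to this change on its own. With compound 1 at a limit and the change a single small substituent, the step from compound 1 to compound 4 is expected to be none beyond the scatter, and compound 4 is expected most often to be reported as a limit as well. The step expected a number no higher from compound 1 to compound 4 (the limit leaves the size open) is small. Compound 4 is estimated at 40000 nM in this assay, with a range from 10000 nM to 40000 nM.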

Compound 4, half-maximal inhibitory concentration: > 40000 nM
Compound 4 was reported as a limit; the forecaster's own chance of this, stated with the estimate: 75%; the middle value lies on the limit itself.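

Compound 4 gives > 40000 nM, a limit and not a number. Compound 1 also stands at a limit, so no step can be read between compound 1 and compound 4: the limit of > 40000 nM in this assay, at which 3 of the 4 values shown sit.

As far as these compounds go, whether the change from phenyl to 4-fluorophenyl has any effect on activity remains open, as does which structural difference separates compound 2 from the compounds at the limit.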